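This account rests on a few compounds, and the source may have more. Where it says the series, first, only, none or still open, it means among the compounds named here.

Measured so far in a functional assay on A549 cells (Homo sapiens) for cytotoxicity, read by MTT assay, with a stated time of 48 h; a higher number here means a weaker inhibitor, a lower number a stronger inhibitor:
- compound 1 `COc1c(OCCCCN2CCNCC2)cc(O)c2c(=O)cc(-c3ccccc3)oc12`: 1740 nM
- compound 2 `COc1c(OCCCCN2CCCC2)cc(O)c2c(=O)cc(-c3ccccc3)oc12`: 1530 nM
- compound 3 `COc1c(OCCCNCc2ccccc2)cc(O)c2c(=O)cc(-c3ccccc3)oc12`: 1570 nM

These three values cannot be told apart, and compound 3, at 1570 nM, sits within the scatter of both neighbours. Compound 4 `COc1c(OCCCN2CCN(C)CC2)cc(O)c2c(=O)cc(-c3ccccc3)oc12` keeps the core of compound 3 but carries 4-methylpiperazin-1-yl in place of benzylamino on a saturated chain carbon, three bonds along the chain from an oxygen on an aromatic ring.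

For the measured compounds named here, no measured compound carries 4-methylpiperazin-1-yl, so the guidance is indirect. The closest case is the change between a piperazin-1-yl group and benzylamino, a 1.1-fold lower number from compound 1 to compound 3 (0.04 log units; within the scatter). Two further changes of the amine also stayed small: a 1.1-fold lower number from compound 1 to compound 2 (0.06 log units; within the scatter) and a 1.0-fold higher number from compound 2 to compound 3 (0.01 log units; within the scatter). Each of these amine swaps left the number within the scatter, so no shift in either direction is expected here beyond it. The expected step is a 1.0-fold higher number from compound 3 to compound 4 (0.01 log units; within the scatter). For compound 4 the estimated value is 1600 nM, with an expected range of 850 nM to 3000 nM.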

Compound 4, half-maximal inhibitory concentration: 9900 nM
Compound 4: the middle estimate sits 6.2-fold (0.79 log units) below what was measured; the whole stated range lies below it.
By their numbers in this assay, from the lowest: compounds 2, 3 and 1 (each within the scatter of the next); then compound 4.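

For the compounds shown here, the end of this chain is not indifferent to the amine it carries: with 4-methylpiperazin-1-yl in place of benzylamino there is a 6.3-fold higher number from compound 3 to compound 4 (0.80 log units; beyond the scatter), so the flat picture from the earlier compounds held only for those amines. The group also stands apart from the other two, with a 6.5-fold higher number from compound 2 to compound 4 (0.81 log units; beyond the scatter) and a 5.7-fold higher number from compound 1 to compound 4 (0.76 log units; beyond the scatter), but these two steps replace (pyrrolidin-1-yl)methyl and (piperazin-1-yl)methyl, so they change the chain as well as the amine. Nothing measured here accounts for the weaker number.

The compounds shown do not separate the methyl on the ring from the length of the chain. A plain piperazin-1-yl on the chain of compound 4 would speak to that, and a morpholin-4-yl there would test whether the second ring nitrogen matters at all.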